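This account rests on a few compounds, and the source may have more. Where it says the series, first, only, none or still open, it means among the compounds named here.

Measured so far in a functional assay on the whole organism with Rattus norvegicus as the target; on this read-out higher numbers stand for an effect only at larger amounts of compound and lower numbers for an effect already at smaller amounts:
- compound 1 `CCOCCOC(=O)C(=O)Nc1nc(-c2cc(C)on2)cs1`: 2 mg/kg
- compound 2 `CCOCCOC(=O)C(=O)Nc1nc(-c2cc(-c3ccccc3)on2)cs1`: 13 mg/kg
- compound 3 `Cc1cc(-c2csc(NC(=O)C(=O)O)n2)no1`: 17 mg/kg

Compound 3 at 17 mg/kg lies within the scatter of compound 2 at 13 mg/kg. The gap to the lowest number in the series is an 8.5-fold higher number from compound 1 to compound 3 (0.93 log units; beyond the scatter).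

Compound 4 `O=C(O)C(=O)Nc1nc(-c2cc(-c3ccccc3)on2)cs1` differs from compound 3 as follows: phenyl in place of methyl on an aromatic carbon. The same exchange, phenyl in place of methyl on an aromatic carbon, has been measured once, in the pair carrying 2-ethoxyethyl: a 6.5-fold higher number from compound 1 to compound 2 (0.81 log units; beyond the scatter). The other measured step, hydrogen in place of 2-ethoxyethyl on an oxygen next to a carbonyl group, leads from compound 2 to compound 4 if it carries over, and it points the same way with a similar size. Each change rests on a single pair, and no data show whether the two changes add fully. A somewhat smaller step is therefore expected in this assay: a 5.3-fold higher number from compound 3 to compound 4 (0.72 log units; beyond the scatter).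

Compound 4 is estimated at 90 mg/kg, with an expected range of 30 mg/kg to 260 mg/kg.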

Compound 4, dose for half-maximal effect: 2.6 mg/kg
Compound 4: the middle estimate sits 35-fold (1.54 log units) above what was measured; measured number below the stated range.
By their numbers in this assay, from the lowest: compounds 1 and 4 (each within the scatter of the next); then compounds 2 and 3 (each within the scatter of the next).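

In this assay, phenyl in place of methyl on an aromatic carbon next to the ring oxygen has no fixed effect. Without the 2-ethoxyethyl group it gives a 6.5-fold lower number from compound 3 to compound 4 (0.82 log units; beyond the scatter), the opposite direction to the step on the core carrying 2-ethoxyethyl: the same change on two cores in this assay, a 6.5-fold higher number (0.81 log units; beyond the scatter) from compound 1 to compound 2 and a 6.5-fold lower number (0.82 log units; beyond the scatter) from compound 3 to compound 4, 43-fold (1.63 log units) apart, beyond the scatter of two such steps. Hydrogen in place of 2-ethoxyethyl likewise depends on the group at this ring position, with the number falling when phenyl is present and rising when methyl is present, as in a 5.0-fold lower number from compound 2 to compound 4 (0.70 log units; beyond the scatter): the same change on two cores in this assay, an 8.5-fold higher number (0.93 log units; beyond the scatter) from compound 1 to compound 3 and a 5.0-fold lower number (0.70 log units; beyond the scatter) from compound 2 to compound 4, 43-fold (1.63 log units) apart, beyond the scatter of two such steps.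

The two changes therefore do not add across these compounds, and the data give no reason for the reversal. On these data alone, it remains open whether the reversal persists with an ethyl or a 4-chlorophenyl group at this position, or with a simple ethyl group in place of 2-ethoxyethyl.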